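Cyclopropyl amide from compound 1: solubility outlook

A few compounds are considered here, and "the series" means these few. Any claim that something is new, unique, unknown or untested is made for them only; others in the source may bear on it.

Compound 1 `CNC(=O)c1cc(C(=O)N[C@H]2[C@@H]3C[C@@H](O)C[C@@H]32)n([C@@H](C)c2ccccc2)n1` is the reference point of this note. In a physicochemical assay for solubility (a higher number here means a more soluble compound, a lower number a less soluble compound), compound 1 gives >= 291 ug/mL, which is a limit of the assay and not a number. Compound 2 `CNC(=O)c1cc(C(=O)NC(C)CO)n([C@@H](C)c2ccccc2)n1` gives >= 132 ug/mL in this assay, again a limit. Compound 3 `CNC(=O)c1cc(C(=O)N[C@H]2CC[C@H](O)CC2)c([C@@H](C)c2ccccc2)o1` gives >= 184 ug/mL in this assay, also a limit. Compound 1 thus stands at the limit of >= 291 ug/mL in this assay, at which 1 of the 3 values shown sits. The reading of compound 2 sits at the limit of >= 132 ug/mL in this assay, at which 1 of the 3 values shown sits. The reading of compound 3 sits at the limit of >= 184 ug/mL in this assay, at which 1 of the 3 values shown sits. Going by the values given here, no measured compound has a numerical reading. The step that the two limits leave unreadable from compound 1 to compound 2 is the only one measured on the same amide-type nitrogen. Compound 4 `CNC(=O)c1cc(C(=O)NC2CC2)n([C@@H](C)c2ccccc2)n1` differs from compound 1 by a group of 3 heavy atoms (3 carbon; one three-membered non-aromatic ring of carbon only) in place of a group of 7 heavy atoms (6 carbon, 1 oxygen; one three-membered non-aromatic ring of carbon only, one five-membered non-aromatic ring of carbon only), on an amide-type nitrogen. Among the compounds with values here, since the one comparable step is unreadable, no measured step gives a size or a direction for this change, and the expected step of an at least 2.4-fold lower number from compound 1 to compound 4 (0.38 log units; beyond the scatter) is set near zero with wide uncertainty. Compound 4 is expected to show 120 ug/mL in this assay, within 30 ug/mL to 400 ug/mL, with a fair chance that only a limit is reported.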

Compound 4, solubility: >= 165 ug/mL
Compound 4: only a limit was reported; the forecaster's own chance of this, stated with the estimate: 40%; at least 1.3-fold (0.13 log units) between middle value and limit.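

In this assay compound 4 gives >= 165 ug/mL, a limit and not a number. Compound 1 and compound 2 also gave only limits, so neither step to compound 4 can be read. The compounds shown leave open whether the group on the amide-type nitrogen shifts the read-out in this assay at all.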